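Removing the Benzoylmethylsulfanyl Arm from Compound 1

This account rests on a few compounds, and the source may have more. Where it says the series, first, only, none or still open, it means among the compounds named here.

Measured so far:
- Compound 1, `Cc1cc(Nc2cc(-c3ccccc3)[nH]n2)n2nc(SCC(=O)c3ccccc3)nc2n1`: 2580 nM
- Compound 2, `COc1ccc(Cn2ccc(Nc3cc(C)nc4nc(SCc5ccc(Br)cc5)nn34)n2)cc1`: 12600 nM

In a functional assay on MGC-803 cells (Homo sapiens) for inhibition, read by MTT assay, with a stated time of 72 h (on this read-out higher numbers stand for weaker inhibition and lower numbers for stronger inhibition), compound 1 gives 2580 nM, the lowest of the two numbers, and compound 2 gives 12600 nM, a gap beyond the scatter. Compound 3, `Cc1cc(Nc2cc(-c3ccccc3)[nH]n2)n2ncnc2n1`, is not yet measured. It differs from compound 1 in one place: hydrogen in place of (benzoylmethyl)sulfanyl on an aromatic carbon. Going by the values given here, no measured pair isolates this change, so the account rests on compound 1 alone. The step is expected to weaken inhibition beyond the scatter, a 3.1-fold higher number from compound 1 to compound 3 (0.49 log units; beyond the scatter). Compound 3 is therefore estimated at 8000 nM, within a range from 2500 nM to 30000 nM.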

Compound 3, half-maximal inhibitory concentration: 21700 nM
Compound 3: the middle estimate sits 2.7-fold (0.43 log units) below what was measured, within the range that was stated.
By their numbers in this assay, from the lowest: compound 1; then compounds 2 and 3 (each within the scatter of the next).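

In this assay, the first pair isolating this change shows that hydrogen in place of (benzoylmethyl)sulfanyl, on the aromatic carbon between two ring nitrogen atoms, gives an 8.4-fold higher number from compound 1 to compound 3 (0.92 log units; beyond the scatter) and thus weaker inhibition. The arm therefore counts for inhibition in the setting of compound 1, although compound 3 still gives a measured value without it. Nothing available here accounts for the size of this step.

As far as these compounds go, it remains open which part of the arm matters, the sulfur, the carbonyl or the terminal aromatic ring. A smaller methylsulfanyl group or an amine at this carbon would test that.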